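A Single Chain Stereocentre Changed, Starting From a Limit

A few compounds are considered here, and "the series" means these few. Any claim that something is new, unique, unknown or untested is made for them only; others in the source may bear on it.

Of the compounds shown here, two have been tested in a functional assay on BL2/B95 cells for cytotoxicity, read by MTT assay, with a stated time of 24 h (on this read-out higher numbers stand for weaker inhibition and lower numbers for stronger inhibition), and neither returned a number. Compound 1 (`CC(C)=CCC[C@@H](C)[C@@H]1C=C[C@]2(C(=O)O)[C@@H](CC(C)=C[C@H]2/C=C(\C)[C@H]2CC[C@H](C(=O)O)CC2)C1`) gives > 20000 nM as a limit of the assay. Compound 2 (`CC(C)=CCC[C@H](C)[C@@H]1C=C[C@]2(C(=O)O)[C@@H](CC(C)=C[C@H]2/C=C(\C)c2ccc(C(=O)O)cc2)C1`) gives > 20000 nM, again a limit. Compound 2 therefore stands at the limit of > 20000 nM in this assay, at which 2 of the 2 values shown sit, and offers no exact potency as a starting point. Compound 3 (`CC(C)=CCC[C@@H](C)[C@@H]1C=C[C@]2(C(=O)O)[C@@H](CC(C)=C[C@H]2/C=C(\C)c2ccc(C(=O)O)cc2)C1`) has the two compounds have the same atoms and bonds and differ only in configuration as drawn: 1 of 6 stereo elements differ; a stereocentre at a saturated chain carbon is drawn S in compound 2 and R in compound 3 and so keeps everything else in compound 2 unchanged: a stereocentre at a saturated chain carbon is drawn S in compound 2 and R in compound 3. Going by the values given here, no measured step shows what such a change does here. With compound 2 at its limit of > 20000 nM in this assay, no change beyond the scatter is expected. The expected step that the limit leaves unreadable from compound 2 to compound 3 is accordingly small. The estimate for compound 3 is 25000 nM, with an expected range from 10000 nM to 60000 nM and a good chance of another limit.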

Compound 3, half-maximal inhibitory concentration: 8600 nM
Estimate against measurement, compound 3: 2.9-fold (0.46 log units) above; measured number outside the range, below it.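

In this assay, a change at the saturated chain stereocentre alone is enough to give a measurable number, with an at least 2.3-fold lower number from compound 2 to compound 3 (0.36 log units; beyond the scatter), and nothing else in the structure differs to account for it: the fact that compounds 2 and 3 differ only in the configuration as drawn. Going by these compounds, compound 2 stands at a limit, so the true size of this step stays unknown: the limit of > 20000 nM in this assay, at which 2 of the 3 values shown sit. The aromatic ring matters as well, since 4-carboxyphenyl in place of 4-carboxycyclohexyl gives an at least 2.3-fold lower number from compound 1 to compound 3 (0.36 log units; beyond the scatter), a step that also rests on a limit and so gives only a minimum size.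

The compounds shown leave open how far the number can fall beyond this single measured value. They also do not show whether a methyl ester or an amide in place of the carboxylic acid on the phenyl ring would keep this activity, or whether a longer chain at the stereocentre would.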